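The source may hold more compounds than are shown below. What is called first, only, known or untested is meant among the compounds shown, and "the series" means these compounds.

Working notes on the series. Compound 1 `COc1cccc(CNCCCNc2ccnc3cc(Oc4ccc(C(C)(C)C)cc4)ccc23)c1O` gives 14500 nM in a physicochemical assay for solubility, with a stated time of 18 h, at pH 7.4; on this read-out lower numbers stand for lower solubility and higher numbers for higher solubility. Going by the values given here, compound 2 `COc1cccc(CNCCCNc2ccnc3cc(CC(C)C)ccc23)c1O` gives 4200 nM in this assay; the step of a 3.5-fold lower number from compound 1 to compound 2 (0.54 log units; beyond the scatter) is the only one-place step measured so far, and it concerns the substituent on the aromatic carbon of the core, not the benzylamine end. Compound 3 `COc1ccc(F)cc1CNCCCNc1ccnc2cc(-c3ccc(C(C)(C)C)cc3)ccc12` gives 32000 nM in this assay, the highest of the three numbers; compound 1 is the closest of the other two and compound 2 the furthest.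

Compound 4 `COc1cccc(CNCCCNc2ccnc3cc(-c4ccc(C(C)(C)C)cc4)ccc23)c1O` is not yet measured. It differs from compound 3 by 2-hydroxy-3-methoxyphenyl in place of 5-fluoro-2-methoxyphenyl on a saturated chain carbon bound to an amine nitrogen. Among the compounds with values here, no measured step covers this change: compound 1 and compound 3 differ from each other in two places, so their values show only a combined outcome, and the step of a 3.5-fold lower number from compound 1 to compound 2 (0.54 log units; beyond the scatter) lies at a different position. The data give no direction for this change. The step of a 1.5-fold lower number from compound 3 to compound 4 (0.16 log units; within the scatter) is therefore expected to stay within the scatter or to be small. Compound 4 is estimated at 22000 nM, with a range from 8000 nM to 60000 nM.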

Compound 4, solubility: 32000 nM
Beside the measured number, compound 4's estimate is 1.5-fold (0.16 log units) below it; low and high end bracket the measured number.
By their numbers in this assay, from the lowest: compound 2; then compound 1; then compounds 3 and 4 (each within the scatter of the next).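

In this assay, going by these compounds alone, the change to 2-hydroxy-3-methoxyphenyl in place of 5-fluoro-2-methoxyphenyl on a saturated chain carbon bound to an amine nitrogen gives no change at the digits printed from compound 3 to compound 4 (within the scatter) and so provides the first one-place reading at this position, where these two groups cannot be told apart. On an aromatic carbon, 4-(tert-butyl)phenyl in place of isobutyl gives a 7.6-fold higher number from compound 2 to compound 4 (0.88 log units; beyond the scatter) and 4-(tert-butyl)phenyl in place of 4-(tert-butyl)phenoxy gives a 2.2-fold higher number from compound 1 to compound 4 (0.34 log units; beyond the scatter) and thus the gap in the printed values of compound 1 and compound 3 now traces to the aromatic carbon alone. No data given here explain any of these steps.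

Going by these compounds, one pair of groups says little about the chain position in general, and how a benzyl group carrying a carboxylic acid or an amine would read there remains open. On these data alone, whether the order of the groups on the aromatic carbon holds with 5-fluoro-2-methoxyphenyl also stays open, as only compound 3 carries that group.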